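A Chloro Substituent Tested on Two Related Cores

The source may report more compounds than this note shows. Statements on the series, on what has been measured and on what is new or still open speak of the compounds shown alone.

Compound 1 `O=C(/C(=C/c1ccccc1)CCl)c1ccccc1` and compound 2 `O=C(/C(=C/c1ccc(Cl)cc1)CCl)c1ccccc1` share one core, while compound 3 `C=C(C/C(=C\c1ccccc1)C(=O)c1ccccc1)C(=O)c1ccccc1` is built on another; the difference between the two cores is not broken down here. In a functional assay on T47D cells (Homo sapiens) for inhibition, read by sulforhodamine B assay, with a stated time of 48 h (a lower number here means a stronger inhibitor of growth, a higher number a weaker inhibitor of growth), compound 1 gives 18000 nM, and compound 2 gives 17000 nM. The step between them, a 1.1-fold lower number from compound 1 to compound 2 (0.02 log units; within the scatter), comes from the change (chloro in place of hydrogen on an aromatic carbon). In this assay compound 3 gives 15000 nM, a number that sits within the scatter of both compound 1 and compound 2.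

Compound 4 `C=C(C/C(=C\c1ccc(Cl)cc1)C(=O)c1ccccc1)C(=O)c1ccccc1` has not yet been measured. Within the data shown here, it differs from compound 3 by chloro in place of hydrogen on an aromatic carbon, the same change as the one from compound 1 to compound 2, made at the same kind of place on an aromatic carbon. Because the earlier step of a 1.1-fold lower number from compound 1 to compound 2 (0.02 log units; within the scatter) stayed within the scatter, compound 4 is expected to stand close to compound 3 in this assay, with an expected step of a 1.1-fold lower number from compound 3 to compound 4 (0.03 log units; within the scatter). The estimate for compound 4 is 14000 nM, expected to fall between 7000 nM and 28000 nM.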

Compound 4, concentration for 50% growth inhibition: 19000 nM
Beside the measured number, compound 4's estimate is 1.4-fold (0.13 log units) below it; the measured number falls inside the stated range.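

In this assay the chloro change again stays within the scatter on the core of compound 3 (a 1.3-fold higher number from compound 3 to compound 4 (0.10 log units; within the scatter)). Set side by side, the two steps cannot be told apart: the same change on two cores in this assay, a 1.1-fold lower number (0.02 log units; within the scatter) from compound 1 to compound 2 and a 1.3-fold higher number (0.10 log units; within the scatter) from compound 3 to compound 4, 1.3-fold (0.13 log units) apart, within the scatter of two such steps. For these two pairs, phenyl to 4-chlorophenyl therefore carries from one core to the other without a detectable difference, but it does not show that the change has any real effect on growth inhibition in either core, and two pairs with a single substituent give no general rule for the series.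

The compounds shown leave open whether another group in the same place, such as a methoxy group, an amine or a carboxylic acid, would move the number beyond the scatter on either core. They also leave open whether a step large enough to stand clear of the scatter would carry between these two cores in the same way.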